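This account rests on a few compounds, and the source may have more. Where it says the series, first, only, none or still open, it means among the compounds named here.

Within the data shown here, in a functional assay on HeLa cells (Homo sapiens) for inhibition, read by MTT assay, with a stated time of 72 h (a lower number here means a stronger inhibitor, a higher number a weaker inhibitor), compound 2 `COc1cc(NC(C)CCCNC(=O)NNC(=O)Nc2cccc(C(F)(F)F)c2)c2ncccc2c1` gives 4900 nM, the only actual number so far. Compound 1 `COc1cc(NC(C)CCCNC(=O)NNC(=O)Nc2ccc(F)cc2)c2ncccc2c1` gives >= 250000 nM, which is a limit of the assay. Compound 3 `COc1cc(NC(C)CCCNC(=O)NNC(=O)Nc2cc(C(F)(F)F)cc(C(F)(F)F)c2)c2ncccc2c1` differs from compound 2 by trifluoromethyl in place of hydrogen on an aromatic carbon, with the new group meta to a trifluoromethyl group. Among the measured compounds shown here, the sole measured step bearing on this, an at least 51-fold lower number from compound 1 to compound 2 (1.70 log units; beyond the scatter), is large and brought in the first trifluoromethyl, but it is a single, open-ended comparison. A second such group is therefore expected to give only a modest further drop, with an expected step of a 2.0-fold lower number from compound 2 to compound 3 (0.29 log units; within the scatter). For compound 3 the estimated value is 2500 nM, with an expected range of 700 nM to 8000 nM.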

Compound 3, half-maximal inhibitory concentration: 17000 nM
Estimate against measurement, compound 3: 6.8-fold (0.83 log units) below, and the stated range ends below it.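

In this assay, trifluoromethyl in place of hydrogen, meta to a trifluoromethyl group, reverses the direction of the earlier gain: a 3.5-fold higher number from compound 2 to compound 3 (0.54 log units; beyond the scatter). More trifluoromethyl on this ring therefore does not simply give a lower number, and compound 2 is the strongest of the three compounds shown. Nothing given here accounts for this rise.

The compounds shown leave open whether the earlier gain belongs to the trifluoromethyl group itself or to where it sits on the ring. They also leave open how a chlorine or a nitrile would behave at the position of the new group.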